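Swapping a hexylsulfanyl chain for a cyclohexyl ring

The source may hold more compounds than are shown below. What is called first, only, known or untested is meant among the compounds shown, and "the series" means these compounds.

Compound 3 `CCCCCCSc1nc(C(C)(C)C)ccc1CNC(=O)C(C)c1ccc(NS(C)(=O)=O)c(F)c1` gives 1.5 nM in an assay on cells for antagonist activity at transient receptor potential cation channel subfamily V member 1 (Homo sapiens), read by FLIPR and calcium flux, with a stated time of 6 min (a higher number here means a weaker inhibitor, a lower number a stronger inhibitor), the highest of the three numbers measured; compound 2 `CC(C)CCOc1nc(C(C)(C)C)ccc1CNC(=O)C(C)c1ccc(NS(C)(=O)=O)c(F)c1` gives 0.8 nM and compound 1 `CCC1CCN(c2nc(C(C)(C)C)ccc2CNC(=O)C(C)c2ccc(NS(C)(=O)=O)c(F)c2)CC1` gives 0.1 nM. Compound 4 `CC(C(=O)NCc1ccc(C(C)(C)C)nc1C1CCCCC1)c1ccc(NS(C)(=O)=O)c(F)c1` differs from compound 3 in one place: cyclohexyl in place of hexylsulfanyl on an aromatic carbon. For the measured compounds named here, no measured step exchanges a chain for a carbon ring, but two bear on the position: a 15-fold higher number from compound 1 to compound 3 (1.18 log units; beyond the scatter) and a 1.9-fold higher number from compound 2 to compound 3 (0.27 log units; within the scatter), so a ring here went with a lower number. Compound 4 is therefore expected to show a 3.0-fold lower number from compound 3 to compound 4 (0.48 log units; beyond the scatter), toward a lower number. The estimate for compound 4 is 0.5 nM, with a range from 0.1 nM to 3 nM.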

Compound 4, inhibition constant: 3.1 nM
Compound 4: the middle estimate sits 6.2-fold (0.79 log units) below what was measured; measured number outside the range, above it.
By their numbers in this assay, from the lowest: compound 1; then compounds 2 and 3 (each within the scatter of the next); then compound 4.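

A ring at this position does not by itself give a low number in this assay: changing to cyclohexyl gives a 2.1-fold higher number from compound 3 to compound 4 (0.32 log units; beyond the scatter) and a 3.9-fold higher number from compound 2 to compound 4 (0.59 log units; beyond the scatter), so it does not match either open chain. The ring of 4-ethylpiperidin-1-yl stays well ahead, with a 31-fold higher number from compound 1 to compound 4 (1.49 log units; beyond the scatter), so the kind of ring matters more than simply having one. Nothing measured here explains these differences.

Going by these compounds, whether the gap follows the ring nitrogen or the ethyl group stays open. Plain piperidin-1-yl and 4-ethylcyclohexyl would separate the two.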